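From propanoyloxy to benzoyloxy on a shared core

A few compounds are considered here, and "the series" means these few. Any claim that something is new, unique, unknown or untested is made for them only; others in the source may bear on it.

Compound 1 `C=C1C(=O)[C@@]23C(=O)OC[C@]4(C(=O)CCC(C)(C)[C@H]4C=O)[C@@H]2CC[C@@H]1[C@H]3OC(C)=O`: 1660 nM
Compound 2 `C=C1C(=O)[C@@]23C(=O)OC[C@]4(C(=O)CCC(C)(C)[C@H]4C=O)[C@@H]2CC[C@@H]1[C@H]3OC(=O)CC`: 1780 nM

For the measured compounds named here, in a functional assay on MGC-803 cells (Homo sapiens) for cytotoxicity, read by MTT assay, with a stated time of 72 h (on this read-out lower numbers stand for stronger inhibition and higher numbers for weaker inhibition), compound 2 sits level with compound 1, the only other measured compound. Going by the values given here, the one measured step, a 1.1-fold higher number from compound 1 to compound 2 (0.03 log units; within the scatter), swapped methyl for hydrogen on the same chain. Compound 3 `C=C1C(=O)[C@@]23C(=O)OC[C@]4(C(=O)CCC(C)(C)[C@H]4C=O)[C@@H]2CC[C@@H]1[C@H]3OC(=O)c1ccccc1` changes this chain further: phenyl in place of ethyl on a carbonyl carbon. Among the compounds with values here, no measured step introduces a ring, so that small step guides only loosely, and no shift beyond the scatter is expected. The expected step is a 1.1-fold lower number from compound 2 to compound 3 (0.05 log units; within the scatter). Compound 3 is estimated at 1600 nM, within a range of 650 nM to 4000 nM.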

Compound 3, half-maximal inhibitory concentration: 1920 nM
The estimate for compound 3 lay 1.2-fold (0.08 log units) below the measured number; the range from low to high includes it.
By their numbers in this assay, from the lowest: compounds 1, 2 and 3 (each within the scatter of the next).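

In this assay, phenyl in place of ethyl on the carbonyl carbon gives a 1.1-fold higher number from compound 2 to compound 3 (0.03 log units; within the scatter) and phenyl in place of methyl gives a 1.2-fold higher number from compound 1 to compound 3 (0.06 log units; within the scatter) with both steps within the scatter. The earlier compounds shown here showed only small chains here, whereas compound 3 shows that this place also takes a six-membered aromatic ring of carbon only, with no shift that can be told from the scatter. Nothing available accounts for this result. Still open, from the compounds shown here alone, is whether an amine or a carboxylic acid on that ring, or a longer chain in its place, would leave the number level as well.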